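The source may report more compounds than this note shows. Statements on the series, on what has been measured and on what is new or still open speak of the compounds shown alone.

Measured so far:
- compound 1, `O=C(C1CC12CCC2)N1CCc2nc(C#Cc3ccccc3)sc2C1`: 3.9 nM
- compound 2, `CC1CCCC(C(=O)N2CCc3nc(C#Cc4ccccc4)sc3C2)C1`: 100 nM

Compound 2 gives 100 nM in an assay on HEK293 cells for positive allosteric modulation of metabotropic glutamate receptor 5 (Homo sapiens), read by FLIPR, with a stated time of 1 h (a higher number here means that more compound is needed for the effect, a lower number that less compound is needed), the higher of the two numbers measured, and it stands apart from compound 1 by a 26-fold higher number from compound 1 to compound 2 (1.41 log units; beyond the scatter). Compound 3, `O=C(c1cccc(Cl)c1)N1CCc2nc(C#Cc3ccccc3)sc2C1`, is the next step from compound 2: 3-chlorophenyl in place of 3-methylcyclohexyl on a carbonyl carbon. Among the measured compounds shown here, no measured pair shows an aromatic group taking the place of a saturated ring on this carbonyl carbon, so the only step that bears on the change is the one from compound 1 to compound 2, which shows that the group on the carbonyl carbon moves the number strongly. Its direction for compound 3 cannot be read from the two measured compounds. Because compound 1 gives 3.9 nM with a compact group at this place, a return toward lower numbers is held possible, and compound 3 is expected to give about 25 nM, a step of a 4.0-fold lower number from compound 2 to compound 3 (0.60 log units; beyond the scatter) in this assay, within the wide range 3 nM to 250 nM.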

Compound 3, half-maximal effective concentration: 8.7 nM
The estimate for compound 3 lay 2.9-fold (0.46 log units) above the measured number, within the range that was stated.
By their numbers in this assay, from the lowest: compound 1; then compound 3; then compound 2.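

In this assay, the direction left unsettled by the first two compounds is now fixed for this carbonyl carbon: 3-chlorophenyl in place of 3-methylcyclohexyl gives an 11-fold lower number from compound 2 to compound 3 (1.06 log units; beyond the scatter), a large change with the heavy-atom count the same in both groups and no hydrogen-bond donor or acceptor on either. The comparison with the compact saturated group of compound 1 shows a 2.2-fold higher number from compound 1 to compound 3 (0.35 log units; beyond the scatter), a modest step that is still beyond the scatter, so an aromatic ring at this place stays close to that group while 3-methylcyclohexyl stands well apart from both. Nothing measured here gives a reason for these differences.

The compounds shown leave open whether a plain phenyl or a 3-methoxyphenyl group on this carbonyl carbon would hold the number of compound 3, and so what part the chlorine plays. From the compounds shown here alone, it also remains open whether a plain cyclohexyl group would stay near compound 2 or fall toward compound 1, which would tell whether the high number goes with the six-membered saturated ring or with its methyl.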